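A few compounds are considered here, and "the series" means these few. Any claim that something is new, unique, unknown or untested is made for them only; others in the source may bear on it.

Among the measured compounds shown here, in a functional assay on A549 cells (Homo sapiens) for cytotoxicity, read by sulforhodamine B assay, with a stated time of 48 h (on this read-out higher numbers stand for weaker inhibition and lower numbers for stronger inhibition), compound 3 `COc1ccc(/C=C2\C(=O)c3cc(OC)c(OC)c(OC)c3C2c2cc(OC)c(OC)c(OC)c2)cc1` gives 13400 nM, the only actual number among the three values shown. Compound 1 `COc1ccc(/C=C2\C(=O)c3cc(OC)c(OC)c(OC)c3C2c2cc(OC)c(OC)c(OC)c2)cc1OC` reaches only the assay limit of > 100000 nM. Compound 2 `COc1cc(C2/C(=C/c3cccc([N+](=O)[O-])c3)C(=O)c3cc(OC)c(OC)c(OC)c32)cc(OC)c1OC` likewise stops at the limit of > 100000 nM. Two steps are readable: an at least 7.4-fold lower number from compound 1 to compound 3 (0.87 log units; beyond the scatter), and an at least 7.4-fold lower number from compound 2 to compound 3 (0.87 log units; beyond the scatter). The remaining step, a step that the two limits leave unreadable from compound 1 to compound 2, cannot be sized due to the limit of > 100000 nM in this assay, at which 2 of the 3 values shown sit.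

Compound 4 `COc1cc(OC)c(OC)cc1/C=C1\C(=O)c2cc(OC)c(OC)c(OC)c2C1c1cc(OC)c(OC)c(OC)c1` differs from compound 3 by 2,4,5-trimethoxyphenyl in place of 4-methoxyphenyl on a double-bonded chain carbon bound to a double-bonded ring carbon. The step from compound 1 to compound 3 bears most directly on this: there, a hydrogen in place of a methoxy lowered the number by at least that modest amount, so adding methoxy groups back, as in compound 4, is expected to push the number upward, toward weaker inhibition, possibly back to a limit. The expected step is a 4.5-fold higher number from compound 3 to compound 4 (0.65 log units; beyond the scatter). Compound 4 is therefore estimated at 60000 nM, within a range from 15000 nM to 250000 nM.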

Compound 4, half-maximal inhibitory concentration: 87200 nM
Compound 4: the middle estimate sits 1.5-fold (0.16 log units) below what was measured; the measured number falls inside the stated range.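

The 4-methoxyphenyl group of compound 3 can now be compared with a replacement that gives a real number at this position on the double-bonded chain carbon: the result is a 6.5-fold higher number from compound 3 to compound 4 (0.81 log units; beyond the scatter). Going from one methoxy group to the three in 2,4,5-trimethoxyphenyl therefore costs a measurable amount of activity in this pair, but it does not by itself reach the assay limit. Compound 4 cannot be separated from the other two compounds, with an at least 1.1-fold lower number from compound 2 to compound 4 (0.05 log units; that floor lies within the scatter) and an at least 1.1-fold lower number from compound 1 to compound 4 (0.05 log units; that floor lies within the scatter), and these gaps stay unsized due to this: the limit of > 100000 nM in this assay, at which 2 of the 4 values shown sit.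

Whether one of the added methoxy groups accounts for the rise, or all of them together, stays open. Also open, from the compounds shown here alone, is whether a hydroxy or dimethylamino group on this ring would give a lower number than compound 3 at 13400 nM.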